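Removing the Methyl from an Aryl Dithiocarbamate

A few compounds are considered here, and "the series" means these few. Any claim that something is new, unique, unknown or untested is made for them only; others in the source may bear on it.

Compound 1 `Cc1ccc(NC(=S)SCC2=CCOC2=O)cc1` stands lowest of the two numbers in hand: in a functional assay on HeLa cells (Homo sapiens) for antiproliferative activity, read by MTT assay, with a stated time of 72 h (a higher number here means a weaker inhibitor, a lower number a stronger inhibitor), compound 1 gives 5440 nM. Its nearest neighbour, compound 2 `CNC(=S)SCC1=CCOC1=O`, gives 36100 nM in this assay, a gap beyond the scatter. Compound 3 `O=C1OCC=C1CSC(=S)Nc1ccccc1` differs from compound 1 by hydrogen in place of methyl on an aromatic carbon. For the measured compounds named here, no measured pair shows that step, so its size is unknown; a change this small is expected to move the number little, probably within the scatter, with a slight lean toward a weaker inhibitor. Compound 3 is therefore estimated at 8000 nM in this assay, within 3000 nM to 25000 nM, an expected step of a 1.5-fold higher number from compound 1 to compound 3 (0.17 log units; within the scatter).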

Compound 3, half-maximal inhibitory concentration: 111000 nM
Compound 3: the middle estimate sits 14-fold (1.14 log units) below what was measured; measured number outside the range, above it.
By their numbers in this assay, from the lowest: compound 1; then compound 2; then compound 3.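

The methyl on an aromatic carbon, para to a large group, carries much of the activity of compound 1 in this assay. For the compounds shown here, replacing this single carbon with hydrogen gives a 20-fold higher number from compound 1 to compound 3 (1.31 log units; beyond the scatter) and is the first measured step at this position. No measurement shown bears on why a change this small has so large an effect. Going by these compounds, whether an ethyl, a methoxy or a chlorine on the same carbon would keep the number of compound 1 remains open. So does whether a methyl on another carbon of the ring would do the same.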